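The compounds below may be only part of what the source reports. "The series", "measured", "known", "first", "only" and "open" are said of these compounds alone.

In a physicochemical assay for solubility, in phosphate buffer, with a stated time of 18 h (on this read-out higher numbers stand for higher solubility and lower numbers for lower solubility), compound 1 (`N#Cc1c(N)nc2nc(C3CC3)ncc2c1N`) gives 23000 nM and compound 2 (`CC(C)(C)c1nc(CCCCCC#N)c2c(N)c(C#N)c(N)nc2n1`) gives 6000 nM as the lower of the two numbers, a gap beyond the usual scatter. For the measured compounds named here, these two compounds do not differ in just one place, so no measured step guides the next change. Compound 3 (`CC(C)(C)c1nc(-c2ccsc2)c2c(N)c(C#N)c(N)nc2n1`) departs from compound 2 with thiophen-3-yl in place of 5-cyanopentyl on an aromatic carbon. A moderate fall in this assay is expected, an estimated 2.4-fold lower number from compound 2 to compound 3 (0.38 log units; beyond the scatter) resting on the structural change alone. For compound 3 the expected value is 2500 nM with 700 nM to 9000 nM as the estimated range.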

Compound 3, solubility: 40000 nM
Compound 3: the middle estimate sits 16-fold (1.20 log units) below what was measured, outside the stated range (above it).
By their numbers in this assay, from the lowest: compound 2; then compounds 1 and 3 (each within the scatter of the next).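

In this assay, for the compounds shown here, thiophen-3-yl in place of 5-cyanopentyl on this aromatic carbon brings a 6.7-fold higher number from compound 2 to compound 3 (0.82 log units; beyond the scatter) and gives the only step read at this position. It shows that the read-out here depends on the group at this carbon, with a five-membered aromatic ring replacing an open chain that ends in a nitrile. Nothing at hand accounts for this rise. Going by these compounds alone, the single step does not separate losing the nitrile from gaining the ring. On these data alone, how a plain hexyl chain, a phenyl ring or an amine at this carbon would compare remains open.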